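Working notes: methyl for hydrogen on a weak chromene-type pair

The source may report more compounds than this note shows. Statements on the series, on what has been measured and on what is new or still open speak of the compounds shown alone.

Measured so far:
compound 1, `COC(=O)C1=C(N)Oc2ccc(Br)cc2C1CC(=O)c1ccc(Cl)cc1`: 67.6%
compound 2, `COc1cc(Br)cc2c1OC(N)=C(C#N)C2CC(=O)c1ccccc1`: 99.1%

In a functional assay on MCF7 cells (Homo sapiens) for antiproliferative activity, read by sulforhodamine B assay, with a stated time of 72 h, tested at 10 uM (on this read-out higher numbers stand for a weaker effect at the one concentration tested and lower numbers for a stronger effect), compound 1 gives 67.6%. In this assay compound 2 gives 99.1%, the highest of the two numbers, so the weakest effect of the pair at the one concentration tested. The nearest number is that of compound 1, lower by a margin beyond the usual scatter. Compound 1 and compound 2 differ in more than one place, so nothing is said here about which part of the structure carries that gap; only the two values themselves are compared.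

Compound 3, `COc1cc(Br)cc2c1OC(N)=C(C#N)C2CC(=O)c1ccc(C)cc1`, is not yet measured. It differs from compound 2 in one place: methyl in place of hydrogen on an aromatic carbon.

Going by the values given here, no single-point step between measured compounds is available to set the size of this change. With compound 2 already near the top of the scale, the expected step from compound 2 to compound 3 is small, a number 7.1 percentage points lower from compound 2 to compound 3 (within the scatter), most likely none beyond the scatter, with a slight lowering the more probable direction if any.

For compound 3 in this assay the estimate is 92%, expected to fall between 72% and 103%.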

Compound 3, a percentage reported as activity, at one concentration (the size of the read-out at that concentration, not a potency): 116%
The estimate for compound 3 lay 24 percentage points below the measured number; measured number outside the range, above it.
By their numbers in this assay, from the lowest: compound 1; then compound 2; then compound 3.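

The change from phenyl to 4-methylphenyl gives the series its first step in a single place: in this assay the methyl, on an aromatic carbon para to a large group, comes with a number 16.9 percentage points higher from compound 2 to compound 3 (beyond the scatter), which on this read-out is a move towards a weaker effect at the one concentration tested. Going by these compounds alone, this shows that the position is not silent, as the number still moves with a single added carbon even though compound 2 already stood at the top of the pair, and compound 3 gives 116%, the highest number so far. Nothing measured on these compounds accounts for the direction of this step, and the size of one methyl is all that can be stated about the change.

The compounds shown leave open how an ethyl chain, an amine or a carboxylic acid on this same aromatic carbon would read. They also leave open whether methyl for hydrogen at this place moves the number the same way on the core of compound 1, since this single step comes from one pair on one core.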